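A Phenyl Swap on Compounds Inactive Against Colon Cancer Cells

The source may report more compounds than this note shows. Statements on the series, on what has been measured and on what is new or still open speak of the compounds shown alone.

Measured so far in a functional assay on HCT-116 cells (Homo sapiens) for antiproliferative activity, read by MTT assay, with a stated time of 48 h; on this read-out lower numbers stand for stronger inhibition and higher numbers for weaker inhibition:
Compound 1 `N#CC1=C(N)Oc2c(c3nc4ccccc4nc3c3ccccc23)C12C(=O)N(Cc1cnnn1-c1ccc(F)c(Cl)c1)c1ccccc12` gives only the assay limit, > 50000 nM.
Compound 2 `N#CC1=C(N)Oc2c(c3nc4ccccc4nc3c3ccccc23)C12C(=O)N(Cc1cnnn1-c1cc(Cl)ccc1Cl)c1ccccc12` gives only the assay limit, > 50000 nM.
Compound 3 `COc1ccc(-n2nncc2CN2C(=O)C3(C(C#N)=C(N)Oc4c(N)cc5nc6ccccc6nc5c43)c3ccccc32)cc1` gives only the assay limit, > 50000 nM.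

All three compounds share one core and differ only in the aromatic ring attached to the triazole nitrogen. None of them shows a number in this assay; every value is a limit. For the measured compounds named here, the single step between measured compounds, a step that the two limits leave unreadable from compound 1 to compound 2, cannot be read since both of its ends sit at the limit of > 50000 nM in this assay, at which 3 of the 3 values shown sit. Compound 3 therefore stands exactly where the other two stand: at the limit, with nothing in the numbers to separate it from compound 1 or compound 2.

Compound 4 `CCc1cccc(CC)c1-n1nncc1CN1C(=O)C2(C(C#N)=C(N)Oc3c(N)cc4nc5ccccc5nc4c32)c2ccccc21` is the next compound in this series. Going by the values given here, its one difference from compound 3 is 2,6-diethylphenyl in place of 4-methoxyphenyl on an aromatic nitrogen. Among the compounds with values here, no measured step speaks to this change: the only step that exists swaps one aromatic ring for another on the same nitrogen, and its size is unreadable. Compound 4 is thus expected to behave like compound 3, with a step that the limit leaves unreadable from compound 3 to compound 4 that means no measurable movement. For compound 4 the estimate is 60000 nM, with a range from 20000 nM to 200000 nM, and the result is expected most likely to be reported again only as a limit.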

Compound 4, half-maximal inhibitory concentration: 37600 nM
Estimate against measurement, compound 4: 1.6-fold (0.20 log units) above; measured number inside the range.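

Compound 4 is the only compound shown that gives a true number rather than a limit in this assay, so the aromatic nitrogen can carry 2,6-diethylphenyl and still yield a readable result. On these data alone, putting that group in place of 4-methoxyphenyl gives an at least 1.3-fold lower number from compound 3 to compound 4 (0.12 log units; that floor lies within the scatter), and with only a limit for compound 3, the real size of the gap between these two compounds stays unknown, so this pair does not establish a real difference. The other compounds remain at the ceiling of the measurement: the limit of > 50000 nM in this assay, at which 3 of the 4 values shown sit.

The swap removes a methoxy group and brings in two ethyl groups on the same phenyl ring in one move, so these compounds leave open which of those two changes matters, if either does. They also leave open what a longer chain such as propyl or butyl in place of ethyl, or an amine or a carboxylic acid on this ring, would do to the number.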